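Methoxy Added to the Aryl Ring of a Dinitrile

This account rests on a few compounds, and the source may have more. Where it says the series, first, only, none or still open, it means among the compounds named here.

Measured compounds:
- compound 1, `COc1ccc(-c2c(C)c(SC)c(C#N)c(N)c2C#N)cc1`, 37.5%
- compound 2, `Cc1c(-c2ccccc2)c(C#N)c(N)c(C#N)c1N1CCCCC1`, 4.7%

In an assay on isolated protein for inhibition of glucose-6-phosphatase catalytic subunit 1 (Homo sapiens), tested at 100 uM (on this read-out lower numbers stand for less inhibition and higher numbers for more inhibition at the one concentration tested (going by the name of the read-out)), compound 1 gives 37.5%, while compound 2 gives 4.7%. Among the compounds with values here, compound 2 therefore stands lowest of the two numbers, and its only neighbour, compound 1, lies above it by a gap beyond the usual scatter; the two differ in more than one place, so their values alone say nothing about any single change.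

Compound 3, `COc1ccc(-c2c(C)c(N3CCCCC3)c(C#N)c(N)c2C#N)cc1`, is not yet measured. It differs from compound 2 by methoxy in place of hydrogen on an aromatic carbon. Within the data shown here, no measured pair shows this change on its own, so the size of the step in this assay is open. Compound 3 is expected to move upward from compound 2 by a step of a number 7.3 percentage points higher from compound 2 to compound 3 (within the scatter), most likely small and possibly within the scatter. Compound 3 is estimated at 12%, with a range from 0% to 35%.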

Compound 3, a percentage reported as inhibition, at one concentration (the size of the read-out at that concentration, not a potency): 15.7%
The estimate for compound 3 lay 3.7 percentage points below the measured number; the range from low to high includes it.
By their numbers in this assay, from the lowest: compound 2; then compound 3; then compound 1.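

In this assay the change from phenyl to 4-methoxyphenyl, read on its own with the piperidin-1-yl group held fixed, gives a number 11 percentage points higher from compound 2 to compound 3 (beyond the scatter) and so lies beyond the scatter. A methoxy on this aromatic carbon, para to a large group, therefore raises the inhibition read at the one concentration tested for this pair. With the 4-methoxyphenyl held fixed, piperidin-1-yl in place of methylsulfanyl gives a number 21.8 percentage points lower from compound 1 to compound 3 (beyond the scatter) as a second readable step, and nothing measured here accounts for either step.

Whether the methoxy step holds when methylsulfanyl replaces piperidin-1-yl stays open, since no phenyl partner of compound 1 is among the compounds shown. Also open, going by these compounds, is how a hydroxyl, a chlorine or a longer ethoxy chain would read in the methoxy position, or a dimethylamino group in place of piperidin-1-yl.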